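The source may report more compounds than this note shows. Statements on the series, on what has been measured and on what is new or still open speak of the compounds shown alone.

In an assay on HEK293 cells for displacement of a labelled ligand from B1 bradykinin receptor (Homo sapiens), read by scintillation counting (on this read-out higher numbers stand for weaker inhibition and lower numbers for stronger inhibition), the three measured compounds stand as follows:
compound 1 `CN(Cc1ccc(C2=NCCN2)cc1)C(=O)COCCN(C)S(=O)(=O)c1c(Cl)cccc1Cl`, 4.2 nM;
compound 2 `Cc1c(Cl)ccc(S(=O)(=O)N(C)CC(=O)NCC(=O)N(C)Cc2ccc(C3=NCCN3)cc2)c1Cl`, 78 nM;
compound 3 `COc1cc(C)c(S(=O)(=O)N(C)CCOCC(=O)N2CCN(CC3CCN(C)CC3)CC2)c(C)c1`, 4.5 nM.

Compound 1 has the lowest of the three numbers. Compound 3 lies within the scatter of it, so the two cannot be ordered; compound 2 stands beyond the scatter, with a number well above that of compound 1. The unmeasured compound 4 `CN(Cc1ccc(C2=NCCN2)cc1)C(=O)COCCN(C)S(=O)(=O)c1ccccc1C(F)(F)F` is derived from compound 1 by a single change: 2-(trifluoromethyl)phenyl in place of 2,6-dichlorophenyl on a sulfonyl sulfur. Going by the values given here, no step between measured compounds involves this change, so the measured set gives nothing to gauge it by. Compound 4 is expected to give a number somewhat above that of compound 1, a step of a 2.9-fold higher number from compound 1 to compound 4 (0.46 log units; beyond the scatter) in this assay, though a step within the scatter remains possible. The estimate for compound 4 is 12 nM, with a range from 3 nM to 50 nM.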

Compound 4, inhibition constant: 2.8 nM
Compound 4: the middle estimate sits 4.3-fold (0.63 log units) above what was measured; the measured number lies below the stated range.
By their numbers in this assay, from the lowest: compounds 4, 1 and 3 (each within the scatter of the next); then compound 2.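

In this assay the change to 2-(trifluoromethyl)phenyl in place of 2,6-dichlorophenyl on a sulfonyl sulfur gives a 1.5-fold lower number from compound 1 to compound 4 (0.18 log units; within the scatter) and leaves the two compounds unordered. This place therefore tolerates a trifluoromethyl group in place of two chlorine atoms, with two more heavy atoms, without a step beyond the scatter. No measurement given here accounts for this result.

Going by these compounds, whether an unsubstituted phenyl or a methoxyphenyl would fare the same on this sulfur remains open. So does whether the same change would hold on the cores of compound 2 and compound 3.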